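Series notes: permeability before the tert-butylphenyl analogue

This account rests on a few compounds, and the source may have more. Where it says the series, first, only, none or still open, it means among the compounds named here.

Compound 2 `COc1cccc(CNCCCNc2ccnc3cc(Oc4ccc(Cl)cc4)ccc23)c1O` is the reference point here. In an ADME assay for permeability, using PAMPA, with a stated time of 30 min, at pH 7.4 (a lower number here means that the compound crosses the layer more slowly, a higher number that the compound crosses the layer faster), compound 2 gives 317 10^-6 cm/s. Compound 1 `COc1ccccc1Oc1ccc2c(NCCCNCc3ccco3)ccnc2c1` gives 317 10^-6 cm/s in this assay, and compound 3 `Clc1ccc(Oc2ccc3c(NCCCNCc4ccco4)ccnc3c2)cc1` gives 317 10^-6 cm/s; compound 2 therefore stands level with both at the digits shown, with no gap beyond the scatter to either.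

Compound 4 `COc1cccc(CNCCCNc2ccnc3cc(-c4ccc(C(C)(C)C)cc4)ccc23)c1O` is the next member and has not yet been measured. Relative to compound 2 it differs in one place: 4-(tert-butyl)phenyl in place of 4-chlorophenoxy on an aromatic carbon.

Among the measured compounds shown here, two measured steps bear on this. One is no change at the digits printed from compound 1 to compound 3 (within the scatter), where 4-chlorophenyl replaced 2-methoxyphenyl on an oxygen on an aromatic ring. The other is no change at the digits printed from compound 2 to compound 3 (within the scatter), where furan-2-yl replaced 2-hydroxy-3-methoxyphenyl on a saturated chain carbon bound to an amine nitrogen. For the measured compounds named here, neither matches the change in compound 4 exactly: no measured pair has 4-(tert-butyl)phenyl entering where 4-chlorophenoxy leaves. Going by the values given here, still, every step so far has left this assay unmoved, so the expected step is no change at the digits printed from compound 2 to compound 4 (within the scatter), nothing beyond the scatter. Compound 4 is thus estimated at 317 10^-6 cm/s, with a range from 160 10^-6 cm/s to 630 10^-6 cm/s.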

Compound 4, apparent permeability: 237 10^-6 cm/s
The estimate for compound 4 lay 1.3-fold (0.13 log units) above the measured number; the measured number falls inside the stated range.
By their numbers in this assay, from the lowest: compounds 4, 1, 2 and 3 (each within the scatter of the next).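

In this assay, among the compounds shown here, the first measured change on this aromatic carbon of the shared core gives a 1.3-fold lower number from compound 2 to compound 4 (0.13 log units; within the scatter), whereas the earlier steps touched only the group on the oxygen and the group on the saturated chain. The read-out therefore stays within the scatter even when the whole 4-chlorophenoxy group gives way to 4-(tert-butyl)phenyl, an exchange that removes the oxygen and the chlorine and replaces 8 heavy atoms with 10 heavy atoms, all carbon. Nothing at hand accounts for this lack of a step beyond the scatter.

The compounds shown leave open whether a group of another kind on this aromatic carbon, such as an amine or a carboxylic acid, would move the read-out in this assay beyond the scatter. They also leave open whether the exchange of 4-chlorophenoxy for 4-(tert-butyl)phenyl would read the same with furan-2-yl in place of 2-hydroxy-3-methoxyphenyl, or with a longer chain in place of the present one.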